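A few compounds are considered here, and "the series" means these few. Any claim that something is new, unique, unknown or untested is made for them only; others in the source may bear on it.

Measured compounds and their values:
Compound 1, `O=C(O)[C@@H](CC1CCC1)N1C[C@H](CN2CCC(c3cnc4ccc([N+](=O)[O-])cn34)CC2)[C@@H](c2cccc(F)c2)C1`, gives 120 mL/min/kg in an in vivo ADME assay on the whole organism (plasma, Rattus norvegicus) for pharmacokinetics; a higher number here means faster removal of the compound, a lower number slower removal.
Compound 2, `O=C(O)[C@@H](CC1CCC1)N1C[C@H](CN2CCC(CCCc3ccccc3)CC2)[C@@H](c2ccccc2)C1`, gives 27 mL/min/kg in this assay.
Compound 3, `CCc1ccn2c(C3CCN(C[C@H]4CN([C@H](CC5CCC5)C(=O)O)C[C@@H]4c4cccc(F)c4)CC3)cnc2c1`, gives 67 mL/min/kg in this assay.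

Among these three, compound 1 stands at the highest number, that is, it is removed fastest. Its nearest neighbour is compound 3, and the gap is a 1.8-fold lower number from compound 1 to compound 3 (0.25 log units; within the scatter), a difference that lies within the usual scatter of repeated measurements. Within the data shown here, compound 2 lies furthest away, and its gap to compound 1 is beyond the scatter; since compound 2 differs from compound 1 in more than one place, no single step connects them.

Compound 4, `O=C(O)[C@@H](CC1CCC1)N1C[C@H](CN2CCC(c3cnc4ccc(-c5ccccc5)cn34)CC2)[C@@H](c2cccc(F)c2)C1`, is not yet measured. It differs from compound 1 in one place: phenyl in place of nitro on an aromatic carbon. Among the measured compounds shown here, only one measured step touches the same fused two-ring group, and it produced a 1.8-fold lower number from compound 1 to compound 3 (0.25 log units; within the scatter). For the measured compounds named here, that single step is the only guide here, and it points to a small movement. For compound 4 a step within the scatter of this assay, or at most a modest decrease, is therefore expected: a 1.4-fold lower number from compound 1 to compound 4 (0.15 log units; within the scatter). The clearance of compound 4 is estimated at 85 mL/min/kg, with a likely range from 40 mL/min/kg to 180 mL/min/kg.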

Compound 4, clearance: 83 mL/min/kg
For compound 4 the middle estimate is 1.0-fold (0.01 log units) above the measured one; measured number inside the range.
By their numbers in this assay, from the lowest: compound 2; then compounds 3, 4 and 1 (each within the scatter of the next).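

Among these compounds, on an aromatic carbon of the six-membered ring of the fused two-ring group, para to a fused ring, compound 1 and compound 4 differ only in nitro and phenyl, so this is the first step to isolate a single substituent at this position. In this assay the exchange gives a 1.4-fold lower number from compound 1 to compound 4 (0.16 log units; within the scatter) and so stays within the scatter, even though two very different groups are swapped: nitro, with its nitrogen, oxygens and hydrogen-bond acceptors, gives way to a larger, carbon-only aromatic ring with no hydrogen-bond acceptors. The position therefore tolerates this particular exchange without a readable change in clearance, but nothing available here explains that outcome.

The compounds shown leave open whether an amine, a carboxylic acid or a longer chain on this same aromatic carbon would produce a step beyond the scatter. They also leave open whether the exchange of nitro for phenyl would have as small an effect on clearance if the rest of the core of compound 1 were altered.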